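Amino in place of nitro in compound 3

The source may hold more compounds than are shown below. What is called first, only, known or untested is meant among the compounds shown, and "the series" means these compounds.

Measured in a functional assay on T47D cells (Homo sapiens) for antiproliferative activity, read by MTT assay, with a stated time of 72 h (a lower number here means a stronger inhibitor, a higher number a weaker inhibitor), each value a limit of the assay:
compound 1 `CCn1ccnc1-c1cc(OC)c(OC)c(OC)c1` > 100000 nM
compound 2 `CCCCn1ccnc1-c1cc(OC)c(OC)c(OC)c1` > 100000 nM
compound 3 `COc1ccc(OC(=O)c2cc(OC)c(OC)c(OC)c2)cc1[N+](=O)[O-]` > 100000 nM

All three compounds give limits and no number, as the limit of > 100000 nM in this assay, at which 3 of the 3 values shown sit, shows. Compound 4 `COc1ccc(OC(=O)c2cc(OC)c(OC)c(OC)c2)cc1N` carries amino in place of nitro on an aromatic carbon, ortho to a methoxy group, as amino in place of nitro on an aromatic carbon counts. Among the compounds with values here, the only measured step, a step that the two limits leave unreadable from compound 1 to compound 2, is a different change in a different place, and it offers no size to carry over. Compound 3 is itself a limit of > 100000 nM, so the expected size in this assay remains very uncertain. The estimated move, an at least 2.5-fold lower number from compound 3 to compound 4 (0.39 log units; beyond the scatter), is expected to be toward stronger inhibition, if a number is reported at all. For compound 4 the estimated value is 40000 nM, with an expected range from 3000 nM to 150000 nM.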

Compound 4, half-maximal inhibitory concentration: > 100000 nM
Compound 4 was reported as a limit (the forecaster's own chance of this, stated with the estimate: 50%); middle value at least 2.5-fold (0.39 log units) away from the limit.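

No step can be read from compound 3 to compound 4, because both compounds give only a limit: the limit of > 100000 nM in this assay, at which 4 of the 4 values shown sit.

The compounds shown leave open whether amino in place of nitro changes the result in this assay at all.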